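Swapping a nitrile chain for an oxolane ring

The source may hold more compounds than are shown below. What is called first, only, known or untested is meant among the compounds shown, and "the series" means these compounds.

compound 1 `CN1C(=S)[C@@H](NC(=O)c2nc(Cc3ccccc3)n(C)n2)COc2ccccc21` gives 2.5 nM
compound 2 `CN1C(=S)[C@@H](NC(=O)c2nc(Cc3ccccc3)n(CCCCC#N)n2)COc2ccccc21` gives 2680 nM
compound 3 `CN1C(=S)[C@@H](NC(=O)c2nc(Cc3ccccc3)n(CCCCCC#N)n2)COc2ccccc21` gives 3830 nM

In a functional assay on HT-29 cells (Homo sapiens) for inhibition, read by luminescence and CellTiter-Glo, with a stated time of 24 h (a higher number here means that more compound is needed for the effect, a lower number that less compound is needed), compound 3 gives 3830 nM and sits close to compound 2, since a 1.4-fold higher number from compound 2 to compound 3 (0.16 log units; within the scatter) is all that separates them. Both lie far from compound 1.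

Compound 4 (`CN1C(=S)[C@@H](NC(=O)c2nc(Cc3ccccc3)n(C3CCOC3)n2)COc2ccccc21`) has oxolan-3-yl in place of 5-cyanopentyl on an aromatic nitrogen. The closest evidence comes from the group on this same nitrogen, which is the only difference among the three measured compounds. Two steps were large: a 1100-fold higher number from compound 1 to compound 2 (3.03 log units; beyond the scatter) and a 1500-fold higher number from compound 1 to compound 3 (3.19 log units; beyond the scatter) show how strongly this assay responds to a change at this place. The step between the two nitrile chains, by contrast, stays within the scatter. Within the data shown here, no measured compound carries a ring here, so the data cannot place oxolan-3-yl precisely.

Compound 4 is expected to recover part of the gap to compound 1, but not all of it, and the uncertainty is wide. The estimated change is a 19-fold lower number from compound 3 to compound 4 (1.28 log units; beyond the scatter) in the direction of a lower number. The estimated value for compound 4 is 200 nM with an expected range (15 nM to 2500 nM).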

Compound 4, half-maximal effective concentration: 1580 nM
For compound 4 the middle estimate is 7.9-fold (0.90 log units) below the measured one; the range from low to high includes it.
By their numbers in this assay, from the lowest: compound 1; then compounds 4, 2 and 3 (each within the scatter of the next, the first and the last beyond it).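

In this assay, exchanging the 5-cyanopentyl chain for the oxolan-3-yl ring produces only a modest change (a 2.4-fold lower number from compound 3 to compound 4 (0.38 log units; beyond the scatter)), and the step from the 4-cyanobutyl chain stays within the scatter (a 1.7-fold lower number from compound 2 to compound 4 (0.23 log units; within the scatter)). The step from methyl remains large (a 630-fold higher number from compound 1 to compound 4 (2.80 log units; beyond the scatter)), so the large loss on this aromatic nitrogen also appears with a group that has a ring and no nitrile, and it does not depend on an open nitrile chain. Nothing at hand explains why the three larger groups lie so far from methyl.

The compounds shown leave open where the large loss begins between methyl and these larger groups, a question that an ethyl group or a cyclopropyl ring could help to answer. They also leave open whether swapping the ring oxygen of oxolan-3-yl for an amine nitrogen, as in a pyrrolidin-3-yl group, would give a number close to that of compound 4 or move it towards compound 1.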